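The source may report more compounds than this note shows. Statements on the series, on what has been measured and on what is new or still open speak of the compounds shown alone.

Compound 1 `CCCCSc1n[nH]c(-n2[se]c3ccccc3c2=O)n1` — 16800 nM
Compound 2 `CCCCCCSc1n[nH]c(-n2[se]c3ccccc3c2=O)n1` — 22400 nM

Both numbers come from a functional assay on SMMC-7721 cells (Homo sapiens) for antiproliferative activity, read by CCK-8 assay, with a stated time of 48 h; on this read-out lower numbers stand for stronger inhibition and higher numbers for weaker inhibition. Among the measured compounds shown here, compound 2 stands at the higher of the two numbers, yet its only neighbour, compound 1, lies within the usual scatter of it: the step of a 1.3-fold higher number from compound 1 to compound 2 (0.12 log units; within the scatter) is too small to count as a real change, so the two compounds are best read as indistinguishable on this read-out.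

Compound 3 `CC(C)Sc1n[nH]c(-n2[se]c3ccccc3c2=O)n1` has not yet been measured. It arises from compound 2 by a single change, isopropyl in place of hexyl on a sulfur — isopropyl in place of hexyl on a sulfur whose other neighbour is an aromatic carbon. For the measured compounds named here, the one measured step that bears on this is a 1.3-fold higher number from compound 1 to compound 2 (0.12 log units; within the scatter), in which the chain on that sulfur was lengthened and the number hardly moved. Shortening and branching the same chain is therefore expected to shift the number little, if at all, beyond the scatter in this assay.

In this assay compound 3 is therefore expected to give 15000 nM, with a range from 6000 nM to 40000 nM. The expected step of a 1.5-fold lower number from compound 2 to compound 3 (0.17 log units; within the scatter) thus stays within the scatter.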

Compound 3, half-maximal inhibitory concentration: 6010 nM
The estimate for compound 3 lay 2.5-fold (0.40 log units) above the measured number; low and high end bracket the measured number.
By their numbers in this assay, from the lowest: compound 3; then compounds 1 and 2 (each within the scatter of the next).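

The chain on the sulfur matters in this assay after all: butyl and hexyl could not be told apart, but isopropyl brings a real change, with a 3.7-fold lower number from compound 2 to compound 3 (0.57 log units; beyond the scatter) and a 2.8-fold lower number from compound 1 to compound 3 (0.45 log units; beyond the scatter), both modest yet beyond the scatter. This position therefore responds to the group placed on it, and among these three compounds the shorter, branched isopropyl goes with the stronger inhibition. No measurement given here explains why this group does better than the two straight chains.

Isopropyl differs from butyl and hexyl in both length and branching, so these compounds cannot show which of the two features goes with the lower number; a straight propyl chain, with the same length as the longest run of carbons in a comparable unbranched group, would help to separate them. Going by these compounds, it also remains open whether a still smaller group such as methyl, a ring such as cyclopropyl or a benzyl group, or a chain ending in a carboxylic acid would lower the number further on this sulfur.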